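A few compounds are considered here, and "the series" means these few. Any claim that something is new, unique, unknown or untested is made for them only; others in the source may bear on it.

In an ADME assay on KB cells (Homo sapiens) for cytotoxicity (on this read-out higher numbers stand for an effect only at larger amounts of compound and lower numbers for an effect already at smaller amounts), compound 1 (`CCOC(=O)N1[C@@H]2C=C[C@@](OC)(C(=O)c3c2cc(OC)c(OC)c3OCc2ccc(F)cc2)N1C(=O)OCC`) gives 51.8 ug/mL as a measured number. Compound 2 (`COc1cc2c(c(OCc3ccc(F)cc3)c1OC)C(=O)[C@]1(OC)C=C[C@H]2N(C(=O)OCC(C)C)N1C(=O)OCC(C)C`) stands at > 300 ug/mL in the same test, and this is only a limit of the assay, not a number. Compound 3 (`COc1cc2c(c(OCc3ccc(Cl)cc3)c1OC)C(=O)[C@]1(OC)C=C[C@H]2N(C(=O)OCC(C)C)N1C(=O)OCC(C)C`) differs from compound 2 in one place (chloro in place of fluoro on an aromatic carbon): chloro in place of fluoro on an aromatic carbon, para to a large group. Going by the values given here, no measured pair shows this change, so the expected shift, a number no higher from compound 2 to compound 3 (the limit leaves the size open) as estimated here, is none beyond the usual scatter. In this assay the estimate for compound 3 is 300 ug/mL with an expected range of 120 ug/mL to 700 ug/mL around it.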

Compound 3, concentration for half-maximal effect: 42 ug/mL
The estimate for compound 3 lay 7.1-fold (0.85 log units) above the measured number, and the stated range ends above it.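

With the rest of the molecule unchanged, going from 4-fluorobenzyl to 4-chlorobenzyl gives an at least 7.1-fold lower number from compound 2 to compound 3 (0.85 log units; beyond the scatter) in this assay, so a single exchange at this position is enough to bring the effect to amounts that the test can put a number on. The true size of the step stays open, as compound 2 gives only a limit of the assay: the limit of > 300 ug/mL in this assay, at which 1 of the 3 values shown sits.

As far as these compounds go, whether bromo, methyl or an amine at this position would move the number in the same way remains open. So does whether chloro in place of fluoro would do the same in compound 1, which carries different side groups.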